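Methyl on the Chromone Core: Expected Cytotoxicity of Compound 3

A few compounds are considered here, and "the series" means these few. Any claim that something is new, unique, unknown or untested is made for them only; others in the source may bear on it.

Compound 1 `O=c1cc(CSc2nc3ccccc3s2)oc2ccccc12` — > 25000 nM in a functional assay on HEp-2 cells (Homo sapiens) for cytotoxicity, read by MTT assay, with a stated time of 72 h; a higher number here means a weaker inhibitor, a lower number a stronger inhibitor
Compound 2 `Cc1ccc2oc(CSc3nc4nc(C)cc(C)n4n3)cc(=O)c2c1` — > 25000 nM

Compound 1 carries a benzothiazole thioether on a chromone. In this assay compound 1 gives > 25000 nM, which is a limit of the assay and not a number. Compound 2 likewise reaches only a limit, > 25000 nM, and so neither of the two measured compounds yields a real number; both sit at the limit of > 25000 nM in this assay, at which 2 of the 2 values shown sit. Compound 1 therefore cannot be ranked against compound 2; the two values show the same limit and nothing more.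

Compound 3 `Cc1ccc2oc(CSc3nc4ccccc4s3)cc(=O)c2c1` differs from compound 1 only by methyl in place of hydrogen on an aromatic carbon. Compound 2 already carries a methyl at the same place on the shared core, with a different heteroaryl thioether, and it too stays at the limit. Among the measured compounds shown here, no measured step links a methylated compound to its unmethylated partner, so the effect of the change is not known from these data. Compound 3 is expected to remain at the limit, with an estimated step that the limit leaves unreadable from compound 1 to compound 3 that is small. For compound 3 the expected value is 50000 nM (from 15000 nM to 200000 nM).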

Compound 3, half-maximal inhibitory concentration: > 25000 nM
Compound 3: only a limit was reported; the forecaster's own chance of this, stated with the estimate: 85%; the middle value does not contradict the limit.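

In this assay compound 3 gives > 25000 nM, which is a limit of the assay and not a number. Compound 1 and compound 3 both stop at a limit, so no step between them can be read: the limit of > 25000 nM in this assay, at which 3 of the 3 values shown sit.

The compounds shown leave open what methyl in place of hydrogen on an aromatic carbon does to the value in this assay.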